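A few compounds are considered here, and "the series" means these few. Any claim that something is new, unique, unknown or untested is made for them only; others in the source may bear on it.

Within the data shown here, compound 2 `COc1cc(N(C)CCN(C)C)c(NC(=O)/C=C\C(C)C)cc1Nc1nccc(-c2cn(C)c3ccc(F)cc23)n1` gives 3920 nM in a functional assay on HepG2 cells (Homo sapiens) for antiproliferative activity, read by MTT assay, with a stated time of 72 h (on this read-out lower numbers stand for stronger inhibition and higher numbers for weaker inhibition), the higher of the two numbers measured; compound 1 `C=CC(=O)Nc1cc(Nc2nccc(-c3cn(C)c4ccc(F)cc34)n2)c(OC)cc1N(C)CCN(C)C` gives 429 nM, and the step of a 9.1-fold higher number from compound 1 to compound 2 (0.96 log units; beyond the scatter) is the only measured step. Compound 3 `COc1cc(N(C)CCN(C)C)c(NC(=O)/C=C\C(C)C)cc1Nc1nc(C)cc(-c2cn(C)c3ccc(F)cc23)n1` carries methyl in place of hydrogen on an aromatic carbon on the shared core. Among the measured compounds shown here, the single measured step concerns the group on the carbonyl carbon, not the six-membered aromatic ring with 2 nitrogen, so it offers no direct guide to this change. The expected step to compound 3 is a 1.0-fold higher number from compound 2 to compound 3 (0.01 log units; within the scatter), within the scatter. The estimate for compound 3 is 4000 nM, range 1500 nM to 11000 nM.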

Compound 3, half-maximal inhibitory concentration: 14000 nM
The estimate for compound 3 lay 3.5-fold (0.54 log units) below the measured number; measured number above the stated range.
By their numbers in this assay, from the lowest: compound 1; then compound 2; then compound 3.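

Among these compounds, this is the first measured change on the six-membered aromatic ring with 2 nitrogen, and the position is not indifferent to substitution. In this assay, methyl in place of hydrogen on the aromatic carbon next to the ring nitrogen gives a 3.6-fold higher number from compound 2 to compound 3 (0.55 log units; beyond the scatter) with the 3-methylbut-1-en-1-yl group kept on the carbonyl carbon. On these data alone, whether this holds with vinyl on the carbonyl carbon, as in compound 1, stays open, as does the outcome for an ethyl, methoxy or amino group at this carbon. Nothing available bears on the reason for this step.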